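Trading a Methyl on Oxygen for Hydrogen: Cytotoxicity Outlook

The source may hold more compounds than are shown below. What is called first, only, known or untested is meant among the compounds shown, and "the series" means these compounds.

Of the compounds shown here, three have been tested in a functional assay on SF-539 cells (Homo sapiens) for cytotoxicity, read by sulforhodamine B assay, with a stated time of 48 h, tested at 1 uM; a lower number here means a stronger effect, a higher number a weaker effect of the compound at the concentration tested. Compound 1 `COc1cc(C)cc(-c2nn(CC#N)cc2-c2ccc(-c3cccc(C(C)=O)c3)nc2)c1` gives -39%, compound 2 `Cc1cc(O)cc(-c2nn(CC#N)cc2-c2ccnc(-c3ccc(Oc4ccccc4)cc3)c2)c1` gives 13%, and compound 3 `COc1cc(C)cc(-c2nn(CC#N)cc2-c2ccnc(-c3ccc(N(C)C)cc3)c2)c1` gives -35%. Compound 3 stands second highest of the three numbers; its value lies within the scatter of compound 1 and far beyond the scatter of compound 2, whose number is much higher. Compound 4 `Cc1cc(O)cc(-c2nn(CC#N)cc2-c2ccnc(-c3ccc(N(C)C)cc3)c2)c1` is compound 3 with one change: hydrogen in place of methyl on an oxygen on an aromatic ring. Compound 2 also carries a hydroxy group, but it differs from compound 3 in another place too, so its higher number cannot be tied to that group alone. The expected step is a number 20 percentage points higher from compound 3 to compound 4 (beyond the scatter), a shift toward a weaker effect that may not clear the scatter. Compound 4 is estimated at -15%, ranging from -40% to 15%.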

Compound 4, a percentage reported as activity, at one concentration (the size of the read-out at that concentration, not a potency): -34%
The estimate for compound 4 lay 19 percentage points above the measured number, and the stated range covers the measured number.
By their numbers in this assay, from the lowest: compounds 1, 3 and 4 (each within the scatter of the next); then compound 2.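

In this assay, changing methoxy to hydroxy on the 3-methoxy-5-methylphenyl group leaves the read-out in place, with a number 1 percentage points higher from compound 3 to compound 4 (within the scatter), so at this position hydrogen can stand in for methyl on the oxygen without a detectable change at this concentration. A change elsewhere does register, with a number 47 percentage points lower from compound 2 to compound 4 (beyond the scatter) when dimethylamino stands in place of phenoxy on an aromatic carbon. Nothing measured here explains either step. Still open, as far as these compounds go, is whether a longer chain on this oxygen, such as ethyl or propyl, or an amine in place of the hydroxy group, would leave the read-out equally unmoved.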